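Dropping a Chloro Group and Its Expected Effect on Cytotoxicity

A few compounds are considered here, and "the series" means these few. Any claim that something is new, unique, unknown or untested is made for them only; others in the source may bear on it.

In a functional assay on SH-SY5Y cells (Homo sapiens) for cytotoxicity, read by MTT assay, with a stated time of 48 h (a higher number here means a weaker inhibitor, a lower number a stronger inhibitor), compound 1 `O=S(=O)(CCC(F)(Cl)C(F)(F)Cl)c1nc2ccccc2s1` gives 4500 nM. Compound 3 `O=S(=O)(CCC(F)(Cl)C(F)(F)Cl)c1nc2ccc(Cl)cc2s1` carries a chloro group on its shared core and gives 6000 nM. The step of a 1.3-fold lower number from compound 3 to compound 1 (0.12 log units; within the scatter) comes from the change (hydrogen in place of chloro on an aromatic carbon). Compound 2 `FC(F)(Cl)C(F)(Cl)CCSc1nc2ccc(Cl)cc2s1` is reported only as a limit of this assay, > 120000 nM; that is the limit of > 120000 nM in this assay, at which 1 of the 3 values shown sits. How the core of compound 2 differs from the core of compound 3 is not broken down here. Compound 4 `FC(F)(Cl)C(F)(Cl)CCSc1nc2ccccc2s1` differs from compound 2 by hydrogen in place of chloro on an aromatic carbon, which is the same change as that from compound 3 to compound 1. Because a 1.3-fold lower number from compound 3 to compound 1 (0.12 log units; within the scatter) lies within the scatter, the step that the limit leaves unreadable from compound 2 to compound 4 is expected to be similarly small. Compound 4 is therefore estimated at 150000 nM, most likely again reported only as a limit.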

Compound 4, half-maximal inhibitory concentration: > 120000 nM
Compound 4 ended at the assay's limit; the forecaster's own chance of this, stated with the estimate: 70%; the middle value is on the limit's open side.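

Compound 2 and compound 4 are both reported only as limits, so the step between them cannot be read: the limit of > 120000 nM in this assay, at which 2 of the 4 values shown sit. On these data alone, whether hydrogen in place of chloro on an aromatic carbon changes anything in this pair stays open.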